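Adding a Second Methoxy Group to Compound 3

The source may hold more compounds than are shown below. What is called first, only, known or untested is meant among the compounds shown, and "the series" means these compounds.

Compound 3 `COc1ccc(NC(=O)c2ccc(C(=O)O)nc2)cc1` gives 21100 nM in an assay on isolated protein (Gallus gallus) for inhibition of transmembrane prolyl 4-hydroxylase (Homo sapiens); on this read-out higher numbers stand for weaker inhibition and lower numbers for stronger inhibition. Its two companions sit close by: compound 1 `O=C(Nc1ccccc1)c1ccc(C(=O)O)nc1` gives 26500 nM, and compound 2 `COc1ccccc1NC(=O)c1ccc(C(=O)O)nc1` gives 14800 nM, both within the usual scatter of compound 3. Compound 4 `COc1ccc(NC(=O)c2ccc(C(=O)O)nc2)c(OC)c1` differs from compound 3 by methoxy in place of hydrogen on an aromatic carbon. Within the data shown here, two measured steps bear on this change, each a methoxy put in place of hydrogen: they led to a 1.8-fold lower number from compound 1 to compound 2 (0.25 log units; within the scatter) and to a 1.3-fold lower number from compound 1 to compound 3 (0.10 log units; within the scatter). Neither moved beyond the scatter, so the added methoxy in compound 4 is expected to bring at most a small shift, if any, leaning toward a lower number. Compound 4 is accordingly expected to show a 1.4-fold lower number from compound 3 to compound 4 (0.15 log units; within the scatter) in this assay. The estimate for compound 4 is 15000 nM, with a range from 6000 nM to 40000 nM.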

Compound 4, half-maximal inhibitory concentration: 16600 nM
For compound 4 the middle estimate is 1.1-fold (0.04 log units) below the measured one; low and high end bracket the measured number.
By their numbers in this assay, from the lowest: compounds 2, 4, 3 and 1 (each within the scatter of the next).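

Ortho to a large group, the added methoxy gives a 1.3-fold lower number from compound 3 to compound 4 (0.10 log units; within the scatter) in this assay, and the second route to the same compound gives a 1.1-fold higher number from compound 2 to compound 4 (0.05 log units; within the scatter). A methoxy already on the ring therefore does not lift this change beyond the scatter, and the step keeps a similar size on two cores: the same change on two cores in this assay, a 1.8-fold lower number (0.25 log units; within the scatter) from compound 1 to compound 2 and a 1.3-fold lower number (0.10 log units; within the scatter) from compound 3 to compound 4, 1.4-fold (0.15 log units) apart, within the scatter of two such steps. The other pair of steps agrees: the same change on two cores in this assay, a 1.3-fold lower number (0.10 log units; within the scatter) from compound 1 to compound 3 and a 1.1-fold higher number (0.05 log units; within the scatter) from compound 2 to compound 4, 1.4-fold (0.15 log units) apart, within the scatter of two such steps.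

The compounds shown leave open whether a different group at this position, such as an amine or a carboxylic acid, would move the number beyond the scatter.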